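Replacing a Phenyl Ring on a Shared Core: Permeability Outlook

The compounds below may be only part of what the source reports. "The series", "measured", "known", "first", "only" and "open" are said of these compounds alone.

Measured so far:
- Compound 1, `COc1cccc(CNCCCNc2ccnc3cc(-c4ccccc4)ccc23)c1O`: 237 10^-6 cm/s
- Compound 2, `COc1cccc(CNCCCNc2ccnc3cc(Oc4cccc(N(C)C)c4)ccc23)c1O`: 317 10^-6 cm/s
- Compound 3, `COc1ccc(F)cc1CNCCCNc1ccnc2cc(-c3ccccc3)ccc12`: 237 10^-6 cm/s

These three compounds share a core and were tested in an ADME assay for permeability, using PAMPA, with a stated time of 30 min, at pH 7.4; on this read-out higher numbers stand for higher permeability and lower numbers for lower permeability. Compound 3 gives 237 10^-6 cm/s, level with compound 1 and together with it the lowest of the three numbers; the gap to compound 2 is a 1.3-fold higher number from compound 1 to compound 2 (0.13 log units; within the scatter), so all three sit within the scatter of one another.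

The unmeasured compound 4, `COc1ccc(F)cc1CNCCCNc1ccnc2cc(Oc3cccc(N(C)C)c3)ccc12`, differs from compound 3 as follows: 3-(dimethylamino)phenoxy in place of phenyl on an aromatic carbon. The same exchange has already been seen once, where a 1.3-fold higher number from compound 1 to compound 2 (0.13 log units; within the scatter). The other measured step, no change at the digits printed from compound 1 to compound 3 (within the scatter), changes a different part of the molecule and shows that the two cores behave alike here.

For the measured compounds named here, since the one directly comparable step stayed within the scatter, compound 4 is expected to differ from compound 3 by no more than a 1.3-fold higher number from compound 3 to compound 4 (0.10 log units; within the scatter), with no change beyond the scatter. Compound 4 is therefore estimated at 300 10^-6 cm/s, in the range 180 10^-6 cm/s to 480 10^-6 cm/s.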

Compound 4, apparent permeability: 317 10^-6 cm/s
Beside the measured number, compound 4's estimate is 1.1-fold (0.02 log units) below it, and the stated range covers the measured number.
By their numbers in this assay, from the lowest: compounds 1, 3, 2 and 4 (each within the scatter of the next).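

In this assay, 3-(dimethylamino)phenoxy in place of phenyl on an aromatic carbon now gives a 1.3-fold higher number from compound 3 to compound 4 (0.13 log units; within the scatter), so this exchange has been read with 5-fluoro-2-methoxyphenyl on the chain as well as with 2-hydroxy-3-methoxyphenyl. The step at this position is the same in both settings: the same change on two cores in this assay, a 1.3-fold higher number (0.13 log units; within the scatter) from compound 1 to compound 2 and a 1.3-fold higher number (0.13 log units; within the scatter) from compound 3 to compound 4, 1.0-fold (0.00 log units) apart, within the scatter of two such steps. The exchange on the saturated chain carbon bound to an amine nitrogen now gives no change at the digits printed from compound 2 to compound 4 (within the scatter), so it too has been read in two settings, with phenyl and with 3-(dimethylamino)phenoxy on the aromatic carbon: the same change on two cores in this assay, no change at the digits printed (within the scatter) from compound 1 to compound 3 and no change at the digits printed (within the scatter) from compound 2 to compound 4, 1.0-fold (0.00 log units) apart, within the scatter of two such steps.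

On these data alone, every step at this aromatic carbon lies within the scatter, so what would move the number beyond it stays open. How a carboxylic acid or a morpholine on that carbon, or a longer saturated chain, would read in this assay also remains an open question.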